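This account rests on a few compounds, and the source may have more. Where it says the series, first, only, none or still open, it means among the compounds named here.

Measured so far in a functional assay on RS4-11 cells (Homo sapiens) for inhibition, read by CCK-8 assay, with a stated time of 48 h; a lower number here means a stronger inhibitor, a higher number a weaker inhibitor:
- compound 1 `Nc1ccc(Oc2ccccc2-c2ccc(S(=O)(=O)NCCNC(=O)Nc3ccc(Cl)cc3)s2)cc1` gives 13600 nM
- compound 2 `COc1ccc(Oc2ccccc2-c2ccsc2S(=O)(=O)N2CCN(C(=S)Nc3cc(C(F)(F)F)cc(C(F)(F)F)c3)CC2)cc1OC` gives only a limit of the assay, > 50000 nM
- compound 3 `O=C(NCCNS(=O)(=O)c1ccc(-c2ccccc2Oc2ccc([N+](=O)[O-])c([N+](=O)[O-])c2)s1)Nc1cc(C(F)(F)F)cc(C(F)(F)F)c1` gives 2400 nM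

Compound 3 holds the lowest of the two numbers in this assay; compound 1 sits higher by a margin beyond the usual scatter, and compound 2 stands at the limit (the limit of > 50000 nM in this assay, at which 1 of the 3 values shown sits). Among the measured compounds shown here, no two measured compounds differ in a single place, so no step size is known directly.

Compound 4 `O=C(NCCNS(=O)(=O)c1ccc(-c2ccccc2O[C@H]2CC[C@@H](O)CC2)s1)Nc1cc(C(F)(F)F)cc(C(F)(F)F)c1` is not yet measured. It differs from compound 3 in one place: 4-hydroxycyclohexyl in place of 3,4-dinitrophenyl on an oxygen on an aromatic ring. Since the aromatic ring with its two nitro groups leaves and a saturated ring carrying one hydroxyl enters, a weakening step is expected, a 3.3-fold higher number from compound 3 to compound 4 (0.52 log units; beyond the scatter). Compound 4 is estimated at 8000 nM, with a range from 2000 nM to 30000 nM.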

Compound 4, half-maximal inhibitory concentration: 9300 nM
Estimate against measurement, compound 4: 1.2-fold (0.07 log units) below; the range from low to high includes it.
By their numbers in this assay, from the lowest: compound 3; then compounds 4 and 1 (each within the scatter of the next). At a limit, above all of these: compound 2.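

In this assay, 4-hydroxycyclohexyl in place of 3,4-dinitrophenyl on an oxygen on an aromatic ring gives a 3.9-fold higher number from compound 3 to compound 4 (0.59 log units; beyond the scatter). This position therefore accepts a non-aromatic ring carrying a hydroxyl with only a modest step, and compound 4 still gives a number, 9300 nM, rather than a limit. Nothing measured here bears on the cause of this step.

The compounds shown do not separate the loss of the two nitro groups from the loss of the aromatic ring. Also open, on these data alone, is how an unsubstituted phenyl or a plain cyclohexyl would read on this oxygen.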